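The source may hold more compounds than are shown below. What is called first, only, known or untested is meant among the compounds shown, and "the series" means these compounds.

Two compounds of this series have a reading in a functional assay on Ehrlich cells (Mus musculus) for cytotoxicity, read by trypan blue exclusion, with a stated time of 2 h, tested at 25 ug/mL; on this read-out lower numbers stand for a stronger effect and higher numbers for a weaker effect at the one concentration tested. In this assay compound 1 `N#Cc1c(N)[n+]([O-])c2ccc(Cl)cc2[n+]1[O-]` gives 95%. In this assay, among the measured compounds shown here, compound 2 `Cc1c(C(=O)N=[N+]=[N-])[n+]([O-])c2cc(Cl)ccc2[n+]1[O-]` gives 98%, a number that sits with the one for compound 1 within the usual scatter, so no order between the two can be read. Compound 3 `COc1ccc2c(c1)[n+]([O-])c(C(=O)N=[N+]=[N-])c(C)[n+]2[O-]` has not yet been measured; it differs from compound 2 by methoxy in place of chloro on an aromatic carbon. For the measured compounds named here, no measured pair shows this change, so the step is expected to stay within the scatter, in no particular direction. For compound 3 in this assay the estimate is 96%, between 87% and 100%. The expected step is a number 2 percentage points lower from compound 2 to compound 3 (within the scatter).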

Compound 3, a percentage reported as activity, at one concentration (the size of the read-out at that concentration, not a potency): 80.7%
For compound 3 the middle estimate is 15.3 percentage points above the measured one; the whole stated range lies above it.
By their numbers in this assay, from the lowest: compound 3; then compounds 1 and 2 (each within the scatter of the next).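

Methoxy in place of chloro on an aromatic carbon gives a number 17.3 percentage points lower from compound 2 to compound 3 (beyond the scatter) in this assay, so this position bears on the read-out, towards a stronger effect at the one concentration tested. Compound 1 and compound 2 differ in more than one place and could not show this. No available evidence bears on what lies behind the step.

Going by these compounds, whether an amine or ethoxy at this place would give a similar reading stays open. So does whether the same change would hold on the core of compound 1.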